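From compound 1 to compound 4: a much longer chain

This account rests on a few compounds, and the source may have more. Where it says the series, first, only, none or still open, it means among the compounds named here.

In a physicochemical assay for lipophilicity (a lower number here means a more polar compound, a higher number a more lipophilic compound), compound 1 `CCCCS(=O)(=O)c1ccc(O)c(C(=O)Nc2ccc(Br)cc2)c1` gives 4.12 and so stands level with compound 2 `CCCCS(=O)(=O)c1ccc(O)c(C(=O)Nc2ccc(C(F)(F)F)cc2)c1` at 4.14 and well above compound 3 `CS(=O)(=O)c1ccc(O)c(C(=O)Nc2ccc(C(F)(F)F)cc2)c1` at 2.52 on this scale. Compound 4 `CCCCCCCCCCCCS(=O)(=O)c1ccc(O)c(C(=O)Nc2ccc(Br)cc2)c1` differs from compound 1 in one place only, and octyl in place of hydrogen on a saturated chain carbon, four bonds along the chain from a sulfonyl sulfur describes that change. The step of a number 0.02 log units higher from compound 1 to compound 2 (within the scatter) has trifluoromethyl in place of bromo and leaves the chain untouched, so it offers little guidance here. The better guide is the step of a number 1.62 log units lower from compound 2 to compound 3 (beyond the scatter) with hydrogen in place of propyl on the chain itself. Compound 4 gains octyl, a larger piece than the propyl lost in that step, so a rise bigger than that drop is expected, namely a number 4.08 log units higher from compound 1 to compound 4 (beyond the scatter) and well beyond the scatter. Within the data shown here, only this one chain step supports the reasoning, so the range stays wide. For compound 4 the estimated value is 8.2 with an expected range of 7.2 to 9 around it.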

Compound 4, partition coefficient: 8.44
Compound 4: the middle estimate sits 0.24 log units below what was measured, and the stated range covers the measured number.
By their numbers in this assay, from the lowest: compound 3; then compounds 1 and 2 (each within the scatter of the next); then compound 4.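

The chain position bound to the sulfonyl sulfur moves this assay in both directions: the shortening seen earlier gave a number 1.62 log units lower from compound 2 to compound 3 (beyond the scatter), and the lengthening here gives a number 4.32 log units higher from compound 1 to compound 4 (beyond the scatter). The second step is the larger one, and it comes with octyl, a bigger change in chain size than the loss of propyl, so among these compounds a longer chain goes with a higher number and a shorter chain with a lower one. No measurement shown here explains why the chain has this effect.

Going by these compounds, with only methyl, butyl and dodecyl chains on the sulfonyl sulfur, the shape of the trend between them remains open, including where a hexyl chain would fall. On these data alone, it is equally open whether an amine or a carboxylic acid at the end of a long chain would keep the number this high.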